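Aryl ether swap on a piperidinyl-pyridazine imidazole

This account rests on a few compounds, and the source may have more. Where it says the series, first, only, none or still open, it means among the compounds named here.

Measured compounds:
compound 1 `CC(C)(C)c1nnc(-c2ccc(N3CCC(Oc4ccccc4C(F)(F)F)CC3)nn2)s1`, 710 nM
compound 2 `N#Cc1ccccc1OC1CCN(c2ccc(-n3ccnc3)nn2)CC1`, 236 nM
compound 3 `CC(C)c1nnc(-c2ccc(N3CCC(Oc4ccccc4C(F)(F)F)CC3)nn2)s1`, 8.8 nM

In an assay on microsomes from liver for inhibition of acyl-CoA desaturase 1 (Rattus norvegicus) (a higher number here means a weaker inhibitor, a lower number a stronger inhibitor), compound 2 gives 236 nM, the second highest of the three numbers: compound 1 gives 710 nM and compound 3 gives 8.8 nM, so compound 2 sits between them. Compound 4 `CCc1cccc(OC2CCN(c3ccc(-n4ccnc4)nn3)CC2)c1` differs from compound 2 in one place: 3-ethylphenyl in place of 2-cyanophenyl on an oxygen on a saturated carbon. Among the measured compounds shown here, the only measured step, an 81-fold lower number from compound 1 to compound 3 (1.91 log units; beyond the scatter), concerns the group on the shared core at the other end of the molecule and does not touch the aryl ether, so no measured step bears directly on the change from compound 2 to compound 4. On these data alone, the loss of the nitrile and the move to an unsubstituted-to-ethyl ring is untested here, and neither direction is supported by the data. The step from compound 2 to compound 4 is therefore expected to be modest, a 1.1-fold higher number from compound 2 to compound 4 (0.03 log units; within the scatter), with a wide range. Compound 4 is estimated at 250 nM in this assay, between 60 nM and 1000 nM.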

Compound 4, half-maximal inhibitory concentration: 38 nM
The estimate for compound 4 lay 6.6-fold (0.82 log units) above the measured number; the whole stated range lies above it.
By their numbers in this assay, from the lowest: compound 3; then compound 4; then compound 2; then compound 1.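

In this assay, the aryl group on the ether oxygen turns out to influence the number on its own: 3-ethylphenyl in place of 2-cyanophenyl gives a 6.2-fold lower number from compound 2 to compound 4 (0.79 log units; beyond the scatter). Among the compounds shown here, the only earlier step concerned a different group on the shared core, so this is the first sign that the number also moves beyond the scatter at this position. It also shows that the nitrile of compound 2 is not needed for a number this low, since compound 4 has no nitrile and no hydrogen-bond acceptor in this group. Nothing available explains the shift.

This single step cannot separate losing the nitrile from gaining the ethyl or from the different placement on the ring. On these data alone, whether a longer chain such as propyl, or an amine, would serve in place of the ethyl remains open.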